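Swapping the Charged Ring Head at the Chain End

The source may report more compounds than this note shows. Statements on the series, on what has been measured and on what is new or still open speak of the compounds shown alone.

Three compounds of a shared core were measured in an assay on LX2 cells for inhibition of COL1A1 promoter (Homo sapiens), read by a luciferase reporter, with a stated time of 24 h, tested at 20 uM; a lower number here means a weaker effect, a higher number a stronger effect of the compound at the concentration tested. Compound 1 `CN(C)c1ccc2c(=O)c(C(=O)Nc3cc(F)cc(F)c3)cn(-c3ccc(OCCCCCCC[N+]45CCN(CC4)CC5)cc3F)c2n1` gives 9.02%, compound 2 `Cc1cc(OCCCCCCC[n+]2ccccc2)cc(-n2cc(C(=O)Nc3cc(F)cc(F)c3)c(=O)c3ccc(N(C)C)nc32)c1` gives 7.7%, and compound 3 `CC[N+]1(CCCCCCCOc2ccc(-n3cc(C(=O)Nc4cc(F)cc(F)c4)c(=O)c4ccc(N(C)C)nc43)cc2Cl)CCCCC1` gives 14.3%. The numbers place compound 2 at the bottom of the three, yet neither compound 1 nor compound 3 differs from it beyond the usual scatter, so all three show weak effects at the concentration tested.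

Compound 4 `Cc1cc(OCCCCCCC[N+](C)(C)C2CCCCC2)cc(-n2cc(C(=O)Nc3cc(F)cc(F)c3)c(=O)c3ccc(N(C)C)nc32)c1` has not yet been measured. It differs from compound 2 in one place: a group of 9 heavy atoms (8 carbon, 1 nitrogen; one six-membered non-aromatic ring of carbon only) in place of a group of 6 heavy atoms (5 carbon, 1 nitrogen; one six-membered aromatic ring with 1 hetero atom), on a saturated chain carbon, seven bonds along the chain from an oxygen on an aromatic ring. Since every charged head tried so far gave a similar weak read-out, no step beyond the scatter is expected from compound 2 to compound 4, a change estimated at a number 1.3 percentage points higher from compound 2 to compound 4 (within the scatter). Compound 4 is therefore expected to give about 9%, within a range from 0% to 20%.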

Compound 4, a percentage reported as inhibition, at one concentration (the size of the read-out at that concentration, not a potency): 52.5%
For compound 4 the middle estimate is 43.5 percentage points below the measured one; measured number above the stated range.
By their numbers in this assay, from the lowest: compounds 2, 1 and 3 (each within the scatter of the next); then compound 4.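

The charged group at the chain end can matter at this position: in this assay, the one-place change to a group with one six-membered non-aromatic ring of carbon only brings a number 44.8 percentage points higher from compound 2 to compound 4 (beyond the scatter). Both groups carry a net charge of +1, so that charge alone does not separate the two compounds. Nothing available here accounts for the rise.

Still open, on these data alone, is whether the carbon ring or the two methyl groups on the nitrogen matter more. A phenyl ring on that nitrogen would help separate ring type from ring presence.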